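The source may hold more compounds than are shown below. What is called first, only, known or untested is meant among the compounds shown, and "the series" means these compounds.

Three compounds of the series have numbers in a functional assay on MCF7 cells (Homo sapiens) for inhibition, read by sulforhodamine B assay, with a stated time of 72 h; a lower number here means a stronger inhibitor, a higher number a weaker inhibitor. Compound 1 `COc1ccc2cc(C(C)c3nnc4n3N=C(c3ccc(C)cc3)CS4)ccc2c1` gives 11000 nM in this assay, and compound 2 `COc1ccc2cc(C(C)c3nnc4n3N=C(c3ccc([N+](=O)[O-])cc3)CS4)ccc2c1`, which carries a nitro in place of the methyl on the aromatic carbon, gives 18800 nM. Compound 3 `CC(C)Cc1ccc(C(C)c2nnc3n2N=C(c2ccc(Br)cc2)CS3)cc1` gives 9400 nM in this assay. That is the lowest of the three numbers, but the gaps to compound 1 and to compound 2 are both within the scatter, so no ordering among the three can be claimed.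

Compound 4 `COc1ccc(C2=Nn3c(nnc3C(C)c3ccc(CC(C)C)cc3)SC2)cc1` has not yet been measured. It differs from compound 3 in one place: methoxy in place of bromo on an aromatic carbon. Within the data shown here, the only measured step of a comparable kind is the exchange on the same aromatic carbon of the pendant aryl ring, a 1.7-fold higher number from compound 1 to compound 2 (0.23 log units; within the scatter), which did not move the number beyond the scatter. On that basis a change of no more than the scatter is expected for compound 4, so that a 1.0-fold higher number from compound 3 to compound 4 (0.00 log units; within the scatter) is the expected step. Compound 4 is therefore estimated at 9500 nM in this assay, with a likely range from 4500 nM to 20000 nM.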

Compound 4, half-maximal inhibitory concentration: 5200 nM
Estimate against measurement, compound 4: 1.8-fold (0.26 log units) above, and the stated range covers the measured number.
By their numbers in this assay, from the lowest: compounds 4, 3, 1 and 2 (each within the scatter of the next, the first and the last beyond it).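

With compound 4, the aromatic carbon of the pendant aryl ring has now been changed on a second background, and a 1.8-fold lower number from compound 3 to compound 4 (0.26 log units; within the scatter) in this assay again stays within the scatter. The 4-bromophenyl to 4-methoxyphenyl exchange adds a hydrogen-bond acceptor by count where bromo has none, yet this does not separate the two compounds, so this position has so far tolerated all four groups seen there, bromo, methoxy, methyl and nitro, without a step beyond the scatter on either background. No measurement available here accounts for the size of this step.

Going by these compounds, whether an amine or a carboxylic acid on this carbon would shift the number beyond the scatter remains open. Also open, on these data alone, is whether the bromo to methoxy exchange gives a similar step on the background of compound 1.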